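A few compounds are considered here, and "the series" means these few. Any claim that something is new, unique, unknown or untested is made for them only; others in the source may bear on it.

Working notes on the series in a functional assay on MDA-MB-231 cells (Homo sapiens) for cytotoxicity, read by MTT assay, with a stated time of 72 h; a lower number here means a stronger inhibitor, a higher number a weaker inhibitor. Compound 1 `COc1cc2c(Oc3ccc(NC(=O)c4nn(-c5ccc(Br)cc5)c(=O)c5ccccc45)cc3F)ccnc2cc1OCCCN1CCCC1` gives 1160 nM. Compound 2 `COc1cc2c(Oc3ccc(NC(=O)c4nn(-c5ccc([N+](=O)[O-])cc5)c(=O)c5ccccc45)cc3F)ccnc2cc1OCCCN1CCCC1` carries the change nitro in place of bromo on an aromatic carbon and in this assay compound 2 gives 2980 nM; the step is a 2.6-fold higher number from compound 1 to compound 2 (0.41 log units; beyond the scatter). Compound 3 `COc1cc2c(Oc3ccc(NC(=O)c4nn(-c5ccc(Br)cc5)c(=O)c5ccccc45)cc3F)ccnc2cc1OCCCN1CCCCC1` has a core that differs from the core of compound 1 by piperidin-1-yl in place of pyrrolidin-1-yl on a saturated chain carbon, three bonds along the chain from an oxygen on an aromatic ring, and in this assay compound 3 gives 1130 nM. The step of a 1.0-fold lower number from compound 1 to compound 3 (0.01 log units; within the scatter) is within the scatter, so the two cores are read as matched on this read-out.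

Compound 4 `COc1cc2c(Oc3ccc(NC(=O)c4nn(-c5ccc([N+](=O)[O-])cc5)c(=O)c5ccccc45)cc3F)ccnc2cc1OCCCN1CCCCC1` is not yet measured. It differs from compound 3 by nitro in place of bromo on an aromatic carbon. The place of this change is the same word for word as for the change from compound 1 to compound 2, so it is the same change made on the other core. The expectation for compound 4 rests on the earlier pair because a 2.6-fold higher number from compound 1 to compound 2 (0.41 log units; beyond the scatter) was beyond the scatter on a core that differs only by piperidin-1-yl in place of pyrrolidin-1-yl on a saturated chain carbon, three bonds along the chain from an oxygen on an aromatic ring. The step from compound 3 to compound 4 is expected to be a 2.6-fold higher number from compound 3 to compound 4 (0.41 log units; beyond the scatter), close in size to the earlier one. Compound 4 is estimated at 2900 nM, with a range from 1500 nM to 5600 nM.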

Compound 4, half-maximal inhibitory concentration: 2620 nM
Compound 4: middle estimate off by 1.1-fold (0.04 log units), on the high side; the measured number falls inside the stated range.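

In this assay, nitro in place of bromo carries over to the second core, with a 2.3-fold higher number from compound 3 to compound 4 (0.37 log units; beyond the scatter), and the step matches the one on the first core: the same change on two cores in this assay, a 2.6-fold higher number (0.41 log units; beyond the scatter) from compound 1 to compound 2 and a 2.3-fold higher number (0.37 log units; beyond the scatter) from compound 3 to compound 4, 1.1-fold (0.04 log units) apart, within the scatter of two such steps Piperidin-1-yl in place of pyrrolidin-1-yl leaves the two cores matched with nitro present, at a 1.1-fold lower number from compound 2 to compound 4 (0.06 log units; within the scatter), just as they were matched with bromo: the same change on two cores in this assay, a 1.0-fold lower number (0.01 log units; within the scatter) from compound 1 to compound 3 and a 1.1-fold lower number (0.06 log units; within the scatter) from compound 2 to compound 4, 1.1-fold (0.04 log units) apart, within the scatter of two such steps This agreement rests on a single pair of groups and on two cores that differ in one place only, so it does not show that the step would carry over to a core that differs elsewhere, and it gives no reason why the nitro compounds read higher than the bromo compounds.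

The compounds shown leave open how a methoxy group or an amine in place of bromo would read in this assay. Also open, as far as these compounds go, is whether the step would hold with morpholin-4-yl in place of piperidin-1-yl, or with a longer chain carrying the ring.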